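Fluorine Added to Compound 2: A Step Without Precedent

The source may report more compounds than this note shows. Statements on the series, on what has been measured and on what is new or still open speak of the compounds shown alone.

For the measured compounds named here, compound 2 `Cn1cnc2c(SCc3ccccc3)ncnc21` stands at the bottom of the two numbers measured so far. In an assay on isolated protein for inhibition of Rho-associated protein kinase 1 (Homo sapiens), tested at 30 uM (a higher number here means more inhibition at the concentration tested (going by the name of the read-out), a lower number less inhibition), compound 2 gives 1%. Its nearest measured neighbour is compound 1 `c1ccc(CSc2ncnc3[nH]cnc23)cc1`, which in this assay gives 28%. Going by the values given here, the one measured step, a number 27 percentage points lower from compound 1 to compound 2 (beyond the scatter), came from methyl in place of hydrogen on an aromatic nitrogen and lies beyond the scatter; it is the only guide the data give.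

Compound 3 `Cn1cnc2c(SCc3ccc(F)cc3)ncnc21` differs from compound 2 by fluoro in place of hydrogen on an aromatic carbon. Among the compounds with values here, no measured step touches this kind of change: the single step measured so far concerns an aromatic nitrogen, not a carbon of the six-membered ring, so nothing in the data says whether a fluoro here moves the inhibition at all. Compound 2 already sits near the floor of the read-out, so a further fall could hardly show, while nothing measured argues for a rise. The step is therefore expected to be small, a number 3 percentage points higher from compound 2 to compound 3 (within the scatter), within the scatter. Compound 3 is estimated at 4%, with a range from -5% to 15%.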

Compound 3, a percentage reported as inhibition, at one concentration (the size of the read-out at that concentration, not a potency): 6%
Estimate against measurement, compound 3: 2 percentage points below; the range from low to high includes it.
By their numbers in this assay, from the lowest: compounds 2 and 3 (each within the scatter of the next); then compound 1.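

In this assay, for the compounds shown here, the fluoro group on an aromatic carbon of the six-membered aromatic ring of carbon only, para to a large group, gives the first measured step at a carbon rather than a nitrogen, and that step is a number 5 percentage points higher from compound 2 to compound 3 (within the scatter) on the methylated core. At this place, then, swapping hydrogen for fluoro produces no change that can be told from scatter. Compound 2 at 1% and compound 3 at 6% both stay close to the bottom of the read-out, where a small effect of the fluoro group could not be seen.

The compounds shown leave open whether the same fluoro group would read differently on the core of compound 1, which keeps the hydrogen on the aromatic nitrogen and gives 28% with more room for a step in either direction. They also leave open what a methoxy group, an amine or a carboxylic acid would do at this place, and what a fluoro group would do on another carbon of the ring. No evidence is at hand that bears on this result.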